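Swapping a Trifluoromethyl for a Cyclopropylmethyl on the Oxygen

The source may hold more compounds than are shown below. What is called first, only, known or untested is meant among the compounds shown, and "the series" means these compounds.

Of the compounds shown here, two have been measured in a physicochemical assay for lipophilicity, at pH 7.4; a higher number here means a more lipophilic compound, a lower number a more polar compound. Compound 1 `O=C(O)Cn1nc(Cc2nc3cc(Cl)c(OC(F)(F)F)cc3[nH]2)c2ccccc2c1=O` gives 2.54, and compound 2 `C[C@H](C(=O)O)c1nn(Cc2cn3cc(OCC4CC4)c(Cl)cc3n2)c2ccccc2c1=O` gives 2.39. These two numbers lie within the usual scatter of each other, so neither can be called the more lipophilic. Compound 3 `O=C(O)Cn1nc(Cc2nc3cc(Cl)c(OCC4CC4)cc3[nH]2)c2ccccc2c1=O` has not yet been measured. It differs from compound 1 in a single place: cyclopropylmethyl in place of trifluoromethyl on an oxygen on an aromatic ring. For the measured compounds named here, with no step between measured compounds to build on, compound 3 is expected to move only modestly, if at all, in the lipophilic direction, a step of a number 0.16 log units higher from compound 1 to compound 3 (within the scatter). Compound 3 is therefore estimated at 2.7, between 2.3 and 3.2.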

Compound 3, distribution coefficient: 2.21
For compound 3 the middle estimate is 0.49 log units above the measured one, and the stated range ends above it.
By their numbers in this assay, from the lowest: compounds 3, 2 and 1 (each within the scatter of the next, the first and the last beyond it).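

In this assay, putting cyclopropylmethyl in place of trifluoromethyl on an oxygen on an aromatic ring gives a number 0.33 log units lower from compound 1 to compound 3 (beyond the scatter), so a change at this one position can move the number past the usual scatter. The two groups have the same count of heavy atoms and no hydrogen-bond donors or acceptors, so those counts alone do not separate them. Nothing measured here explains the direction of the step.

From the compounds shown here alone, how a methyl group or a longer chain on the same oxygen would read in this assay stays open, as does whether this step would repeat on a different core.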